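Swapping the amide aryl group on a cytotoxicity series

The source may report more compounds than this note shows. Statements on the series, on what has been measured and on what is new or still open speak of the compounds shown alone.

Measured so far:
Compound 1, `COc1cc2nc([S+]([O-])CC(=O)Nc3ccc(F)cc3)nc(Nc3c(C)cc(/C=C/C#N)cc3C)c2cc1OC`: 27400 nM
Compound 2, `COc1cc2nc([S+]([O-])CC(=O)Nc3ccc([N+](=O)[O-])cc3)nc(Nc3c(Cl)cc(/C=C/C#N)cc3Cl)c2cc1OC`: 92800 nM

The two compounds were tested in an ADME assay on MT4 cells (Homo sapiens) for cytotoxicity, read by MTT assay, with a stated time of 5 days; on this read-out lower numbers stand for higher toxicity in this test and higher numbers for lower toxicity in this test. Compound 1 gives 27400 nM, while compound 2 gives 92800 nM, the higher of the two numbers and therefore the less toxic of the pair in this assay. The gap between them is beyond the scatter, but the two compounds differ in several places at once, so no single structural change can be tied to it.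

Compound 3, `COc1ccccc1NC(=O)C[S+]([O-])c1nc(Nc2c(Cl)cc(/C=C/C#N)cc2Cl)c2cc(OC)c(OC)cc2n1`, has not yet been measured. It shares the core of compound 2 and differs from it only at one point: 2-methoxyphenyl in place of 4-nitrophenyl on an amide-type nitrogen. Within the data shown here, no step for a change of this kind has been measured here, so the expectation rests on the values of compounds 1 and 2 alone. The step from compound 2 to compound 3 is estimated to be small and downward, a 1.5-fold lower number from compound 2 to compound 3 (0.19 log units; within the scatter), possibly within the scatter. Compound 3 is expected to give about 60000 nM in this assay, in a range from 20000 nM to 150000 nM.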

Compound 3, half-maximal cytotoxic concentration: > 204000 nM
Compound 3: only a limit was reported; the forecaster's own chance of this, stated with the estimate: 20%; middle value at least 3.4-fold (0.53 log units) from the limit.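

With the shared core unchanged, one change on the amide-type nitrogen can now be read alone: 2-methoxyphenyl in place of 4-nitrophenyl gives an at least 2.1-fold higher number from compound 2 to compound 3 (0.34 log units; beyond the scatter) in this comparison. This shows that the aryl group at this place can shift the read-out, and here the shift is towards lower toxicity in this test. In this assay compound 3 gives > 204000 nM as its result, which is a limit of the assay and not a number, so the step has a lower bound but no known size: the limit of > 204000 nM in this assay, at which 1 of the 3 values shown sits.

Compound 1 differs from compound 2 and compound 3 in more than one place, so its 4-fluorophenyl group cannot be compared with either aryl group. Going by these compounds, whether the shift follows the loss of 4-nitrophenyl or the arrival of 2-methoxyphenyl stays open, and a plain phenyl or a 4-methoxyphenyl group on the same nitrogen would be needed to separate the two.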